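A few compounds are considered here, and "the series" means these few. Any claim that something is new, unique, unknown or untested is made for them only; others in the source may bear on it.

Compound 1 `CCOC(=O)N1CCC(NS(=O)(=O)c2ccc(C(=O)NC3CCCCC3)c3ccccc23)CC1`: 9.5 nM
Compound 2 `CCOC(=O)N1CCC(NS(=O)(=O)c2ccc(NCc3ccccc3)c3ccccc23)CC1`: 45.6 nM
Compound 3 `Cc1ccccc1C(=O)Nc1ccc(S(=O)(=O)NC2CCN(C(=O)C3CCCC3)CC2)c2ccccc12`: 9.1 nM

These numbers come from an assay on L1.2 cells for binding affinity to C-C chemokine receptor type 8 (Homo sapiens); on this read-out lower numbers stand for stronger inhibition and higher numbers for weaker inhibition. Compound 3 has the lowest of the three, but its gap to compound 1 is within the scatter, so the two cannot be told apart on this evidence; compound 2 is the one that stands clearly apart, with a higher number. Among the compounds with values here, the only measured step, a 4.8-fold higher number from compound 1 to compound 2 (0.68 log units; beyond the scatter), changes a group on an aromatic carbon of the shared core.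

Compound 4 `Cc1ccccc1C(=O)Nc1ccc(S(=O)(=O)NC2CCN(C(=O)N3CCCC3)CC2)c2ccccc12` is the next compound to be tested. It differs from compound 3 in a single place: pyrrolidin-1-yl in place of cyclopentyl on a carbonyl carbon. Within the data shown here, this is a different place from the one varied in the only measured step, so that step does not bear on it, and no measured pair shows a change of this kind. There is therefore nothing in the data to suggest a shift beyond the scatter. For compound 4 the expected step is a 1.1-fold higher number from compound 3 to compound 4 (0.04 log units; within the scatter), judged as within the scatter. Compound 4 is estimated at 10 nM, with a range from 4 nM to 25 nM.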

Compound 4, inhibition constant: 1.1 nM
For compound 4 the middle estimate is 9.1-fold (0.96 log units) above the measured one, and the stated range ends above it.
By their numbers in this assay, from the lowest: compound 4; then compounds 3 and 1 (each within the scatter of the next); then compound 2.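

In this assay, the step of an 8.3-fold lower number from compound 3 to compound 4 (0.92 log units; beyond the scatter) shows that the group on this carbonyl carbon, whose other neighbour is an amide-type nitrogen in a ring, can change the number well beyond the scatter. Within the data shown here, the earlier compounds could not show this, since their only measured step lay at a different place on the shared core. Cyclopentyl and pyrrolidin-1-yl have the same heavy-atom count and each forms one five-membered non-aromatic ring, so the change amounts to a nitrogen replacing a carbon in that ring, but nothing here explains why this shifts the number.

From the compounds shown here alone, it remains open whether a larger ring such as piperidin-1-yl, or an open-chain amine such as diethylamino, would give a similar number at this carbonyl carbon. It is also unknown whether pyrrolidin-1-yl would produce a similar step alongside the cyclohexylcarbamoyl group of compound 1.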